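Replacing 4-methylphenyl with 3,4-dichlorophenyl in compound 3

A few compounds are considered here, and "the series" means these few. Any claim that something is new, unique, unknown or untested is made for them only; others in the source may bear on it.

In a functional assay on HepG2 cells (Homo sapiens) for antiproliferative activity, read by MTT assay, with a stated time of 48 h (a lower number here means a stronger inhibitor, a higher number a weaker inhibitor), compound 1 (`CN(C)c1ccc(NC(=O)Nc2cccc(CNc3nccnc3Cl)c2)cc1`) reads > 40000 nM as a limit and not a number. Compound 2 (`CCc1ccccc1NC(=O)Nc1cccc(CNc2nccnc2Cl)c1`) gives 7860 nM and compound 3 (`Cc1ccc(NC(=O)Nc2cccc(CNc3nccnc3Cl)c2)cc1`) gives 11500 nM as measured values. The data show a 1.5-fold higher number from compound 2 to compound 3 (0.17 log units; within the scatter) so these two cannot be ranked. Larger moves appear as an at least 5.0-fold lower number from compound 1 to compound 2 (0.70 log units; beyond the scatter) and as an at least 3.4-fold lower number from compound 1 to compound 3 (0.54 log units; beyond the scatter) when 4-(dimethylamino)phenyl leaves.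

Compound 4 (`O=C(Nc1cccc(CNc2nccnc2Cl)c1)Nc1ccc(Cl)c(Cl)c1`) carries 3,4-dichlorophenyl in place of 4-methylphenyl on an amide-type nitrogen. All three measured steps change the group at this place, so all bear on the new one. Only those leaving 4-(dimethylamino)phenyl went beyond the scatter, and none brings in 3,4-dichlorophenyl, so only a modest move from compound 3 at 11500 nM is expected. The expected move is a 2.3-fold lower number from compound 3 to compound 4 (0.36 log units; beyond the scatter) and its direction toward a lower number in this assay is tentative. For compound 4 the estimated value is 5000 nM with an expected range from 1800 nM to 15000 nM in this read-out.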

Compound 4, half-maximal inhibitory concentration: 6170 nM
For compound 4 the middle estimate is 1.2-fold (0.09 log units) below the measured one, and the stated range covers the measured number.
By their numbers in this assay, from the lowest: compounds 4, 2 and 3 (each within the scatter of the next). At a limit, above all of these: compound 1.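

In this assay, 3,4-dichlorophenyl on the amide-type nitrogen brings no separation from 4-methylphenyl or 2-ethylphenyl: the data show a 1.9-fold lower number from compound 3 to compound 4 (0.27 log units; within the scatter) and a 1.3-fold lower number from compound 2 to compound 4 (0.11 log units; within the scatter), so these three compounds cannot be ranked. This adds a ring carrying two chlorine atoms to the groups that read alike at this place, and the move away from 4-(dimethylamino)phenyl again goes beyond the scatter, with an at least 6.4-fold lower number from compound 1 to compound 4 (0.81 log units; beyond the scatter). Compound 1 stands as a limit and not a number: the limit of > 40000 nM in this assay, at which 1 of the 4 values shown sits.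

The compounds shown leave open whether a phenyl ring bearing a carboxylic acid, a methoxy group or a primary amine at this place would separate from these three in this assay. They also leave open whether a dimethylamino group elsewhere on the ring would give a reading like that of compound 1.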